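This account rests on a few compounds, and the source may have more. Where it says the series, first, only, none or still open, it means among the compounds named here.

Compound 3 `CCn1cc(C(CC)(CC)c2ccc(C#CC(O)(CC)CC)c(C)c2)cc1C(=O)OCCO` is the starting point. Going by the values given here, in a functional assay on PC-3 cells (Homo sapiens) for antiproliferative activity, read by MTT assay, with a stated time of 72 h (a higher number here means a weaker inhibitor, a lower number a stronger inhibitor), compound 3 gives 11400 nM, the lower of the two true numbers available so far. Compound 1 `CCn1c(C(=O)NCCC(=O)OC)ccc1C(CC)(CC)c1ccc(C#CC(O)(CC)CC)c(C)c1` gives 36300 nM, a higher number by more than the usual scatter. Compound 2 `C#CCCOC(=O)c1ccc(C(CC)(CC)c2ccc(C#CC(O)(CC)CC)c(C)c2)n1CC` gives > 50000 nM, which is a limit of the assay and not a number.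

Compound 4 `CCn1cc(C(CC)(CC)c2ccc(C#CC(O)(CC)CC)c(C)c2)cc1C(=O)N[C@@H](C)CO` differs from compound 3 in one place: (1-(hydroxymethyl)ethyl)amino in place of 2-hydroxyethoxy on a carbonyl carbon. Put simply, (1-(hydroxymethyl)ethyl)amino stands in place of 2-hydroxyethoxy on a carbonyl carbon, and one defined stereocentre comes with it.

Among the compounds with values here, only one measured step offers a comparison, and it runs the opposite way, from an amino group to an oxy group on a carbonyl carbon. There, (but-3-yn-1-yl)oxy stands in place of (2-(methoxycarbonyl)ethyl)amino, which gives an at least 1.3-fold higher number from compound 1 to compound 2 (0.13 log units; that floor lies within the scatter). That step rests on a limit, and its groups are not the ones exchanged here, so it is a weak guide. Within the data shown here, with an at least 1.3-fold higher number from compound 1 to compound 2 (0.13 log units; that floor lies within the scatter) as the only comparison, no step beyond the scatter is expected in this assay. The estimated change is a 1.2-fold higher number from compound 3 to compound 4 (0.09 log units; within the scatter). The estimate for compound 4 is 14000 nM, with an expected range from 5000 nM to 40000 nM.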

Compound 4, half-maximal inhibitory concentration: 6050 nM
Beside the measured number, compound 4's estimate is 2.3-fold (0.36 log units) above it, and the stated range covers the measured number.
By their numbers in this assay, from the lowest: compounds 4 and 3 (each within the scatter of the next); then compound 1. At a limit, above all of these: compound 2.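

In this assay, placing (1-(hydroxymethyl)ethyl)amino instead of 2-hydroxyethoxy on this carbonyl carbon gives a 1.9-fold lower number from compound 3 to compound 4 (0.28 log units; within the scatter), so the two compounds cannot be told apart here, even though the swap turns a (2-hydroxyethoxy)carbonyl into a (1-(hydroxymethyl)ethyl)carbamoyl and brings in a defined stereocentre. The earlier step on a carbonyl carbon ended at a limit for compound 2, which makes this the only exchange shown there that can be read between two true numbers. Nothing measured here bears on why these two numbers fall so close together.

The compounds shown leave open how the other mirror-image form of the stereocentre would read, and whether the hydroxyl at the end of the chain matters, since a plain propylamino group on the same carbonyl carbon is not among them. They also leave open what a free carboxylic acid, or a longer chain ending in a hydroxyl group, would do at this place on the shared core.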